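A few compounds are considered here, and "the series" means these few. Any claim that something is new, unique, unknown or untested is made for them only; others in the source may bear on it.

Values so far in an ADME assay on LLC-PK1 cells (Sus scrofa) for permeability; on this read-out higher numbers stand for higher permeability and lower numbers for lower permeability:
- compound 1 `C[C@]1(c2cc(NC(=O)c3ccc(Cl)cn3)cc(F)c2F)N=C(N)S[C@@]2(C(N)=O)C[C@H]21` - 38 10^-6 cm/s
- compound 2 `COC[C@]12C[C@H]1[C@@](C)(c1cc(NC(=O)c3ccc(OCC(F)(F)F)cn3)cc(F)c1F)N=C(N)S2` - 18 10^-6 cm/s
- compound 3 `C#CCOc1ccc(C(=O)Nc2cc(F)c(F)c([C@@]3(C)N=C(N)S[C@@]4(COC)C[C@H]43)c2)nc1` - 14 10^-6 cm/s

Compound 3 (14 10^-6 cm/s) and compound 2 (18 10^-6 cm/s) lie within the scatter of each other, while compound 1 (38 10^-6 cm/s) shows a higher number, beyond the scatter from compound 3.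

Next in the series is compound 4 `CCCOc1cnc(C(=O)Nc2cc(F)c(F)c([C@@]3(C)N=C(N)S[C@@]4(COC)C[C@H]43)c2)cn1`, with the change 5-propoxypyrazin-2-yl in place of 5-(propargyloxy)pyridin-2-yl on a carbonyl carbon. For the measured compounds named here, one measured step bears on this: a 1.3-fold lower number from compound 2 to compound 3 (0.11 log units; within the scatter) is also a change in the chain on the oxygen, and it stayed within the scatter. Going by the values given here, no measured pair shows the exchange of the aromatic ring, so this support is only partial. No step beyond the scatter is expected in this assay. The estimated move is a 1.1-fold higher number from compound 3 to compound 4 (0.03 log units; within the scatter) and is expected to stay small. In this assay compound 4 is expected at 15 10^-6 cm/s, within an estimated range from 8 10^-6 cm/s to 27 10^-6 cm/s for repeated measurements.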

Compound 4, apparent permeability: 18 10^-6 cm/s
Beside the measured number, compound 4's estimate is 1.2-fold (0.08 log units) below it, within the range that was stated.
By their numbers in this assay, from the lowest: compounds 3, 2 and 4 (each within the scatter of the next); then compound 1.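

In this assay, 5-propoxypyrazin-2-yl in place of 5-(propargyloxy)pyridin-2-yl on a carbonyl carbon gives a 1.3-fold higher number from compound 3 to compound 4 (0.11 log units; within the scatter). Unlike the earlier step, which altered only the chain on the oxygen, this one also replaces the aromatic ring with one holding 2 hetero atoms, and the size of the step still stays within the scatter; the triple bond leaves in the same exchange, so the contributions of ring and chain cannot be separated. No independent measurement is available to account for this result.

Still open, going by these compounds, is the effect of the ring exchange alone, with the chain on the oxygen kept the same. Also open, on these data alone, is whether a longer chain on that oxygen, or a chain ending in an amine or a carboxylic acid, would remain within the scatter of these values.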